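The source may hold more compounds than are shown below. What is called first, only, known or untested is meant among the compounds shown, and "the series" means these compounds.

Measured so far:
Compound 1 `Clc1ccccc1CSc1nnc(-c2ccncc2)n1-c1ccccc1` gives 13900 nM in a functional assay on HCT-116 cells (Homo sapiens) for inhibition, read by MTT assay, with a stated time of 48 h; a higher number here means a weaker inhibitor, a lower number a stronger inhibitor.
Compound 2 `O=C(CSc1nnc(-c2ccncc2)n1-c1ccccc1)N/N=C/c1ccc(Cl)cc1` gives 5740 nM in this assay.

Of the two numbers, compound 2 holds the lower one; compound 1 sits a step above it that lies beyond the usual scatter, so compound 2 is the stronger inhibitor of the pair. The next compound, compound 3 `O=C(CSc1nnc(-c2ccncc2)n1-c1ccccc1)N/N=C/C=C/c1ccccc1`, keeps the whole of compound 2 except at one place: 2-phenylethenyl in place of 4-chlorophenyl on a carbon with a double bond to nitrogen. For the measured compounds named here, no measured pair shows this kind of exchange, so the expectation rests on the single value of compound 2 and on the modest size of the change. The 2-phenylethenyl group keeps one aromatic ring where the 4-chlorophenyl group had one, and the expected step of a 1.1-fold higher number from compound 2 to compound 3 (0.05 log units; within the scatter) is small, if any, and may not exceed the scatter. For compound 3 the estimated value in this assay is 6500 nM, with a range from 2500 nM to 17000 nM.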

Compound 3, half-maximal inhibitory concentration: 6150 nM
Estimate against measurement, compound 3: 1.1-fold (0.02 log units) above, within the range that was stated.
By their numbers in this assay, from the lowest: compounds 2 and 3 (each within the scatter of the next); then compound 1.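

For the compounds shown here, the exchange of 4-chlorophenyl for 2-phenylethenyl on a carbon with a double bond to nitrogen gives a 1.1-fold higher number from compound 2 to compound 3 (0.03 log units; within the scatter) in this assay and is the first reading at this position. Here the chlorine leaves and a double bond outside aromatic rings enters, while one six-membered aromatic ring of carbon only remains in the group, and the read-out does not separate the two compounds. No measured evidence on why these two groups read alike is available.

The compounds shown leave open whether this position would tolerate a group without an aromatic ring, such as a simple alkyl chain, or a phenyl ring carrying an amine or a carboxylic acid. They also leave open how the unsubstituted phenyl group would read here.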